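Swapping an aryl cap for a carbamate on the shared core

The compounds below may be only part of what the source reports. "The series", "measured", "known", "first", "only" and "open" are said of these compounds alone.

Of the compounds shown here, two of one shared core have been measured in an assay on HeLa cells for inhibition of Indoleamine 2,3-dioxygenase 1 (Homo sapiens); on this read-out higher numbers stand for weaker inhibition and lower numbers for stronger inhibition. Compound 1, `O=C(NC1(c2ccc3c(n2)CCN3c2ccnc(C(F)(F)F)n2)CCC1)c1ccc(Cl)cc1`, gives 93 nM, and compound 2, `Cc1nccc(N2CCc3nc(C4(NC(=O)c5ccc(Cl)cc5)CCC4)ccc32)n1`, gives 46 nM. Among the measured compounds shown here, the single step between them, a 2.0-fold lower number from compound 1 to compound 2 (0.31 log units; beyond the scatter), leaves compound 2 with the lowest of the two numbers, with compound 1 a modest distance behind.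

Compound 3, `COCCOC(=O)N1CCc2nc(C3(NC(=O)c4ccc(Cl)cc4)CCC3)ccc21`, has not been measured. It differs from compound 2 in one place: (2-methoxyethoxy)carbonyl in place of 2-methylpyrimidin-4-yl on a nitrogen on an aromatic ring in a ring. For the measured compounds named here, no measured step touches this position in this way; the only step known alters a group on the ring that now departs entirely, and that step was modest. The whole aromatic cap on that nitrogen is replaced by a chain. The change is larger than anything measured here, and its direction cannot be read from the steps. Compound 3 is therefore expected to give a weaker result, with wide uncertainty, around 300 nM, between 60 nM and 1500 nM. This is estimated to amount to a 6.5-fold higher number from compound 2 to compound 3 (0.81 log units; beyond the scatter).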

Compound 3, half-maximal inhibitory concentration: 6.9 nM
Compound 3: the middle estimate sits 43-fold (1.64 log units) above what was measured; measured number below the stated range.
By their numbers in this assay, from the lowest: compound 3; then compound 2; then compound 1.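

In this assay, the nitrogen of the five-membered non-aromatic ring does not need an aromatic cap: replacing 2-methylpyrimidin-4-yl with (2-methoxyethoxy)carbonyl, a group with no ring, gives a 6.7-fold lower number from compound 2 to compound 3 (0.82 log units; beyond the scatter) and the lowest number of the series. The same replacement of 2-(trifluoromethyl)pyrimidin-4-yl gives a 13-fold lower number from compound 1 to compound 3 (1.13 log units; beyond the scatter), so this open chain gives a lower number than both pyrimidine caps, while the heavy-atom count stays at 7 from compound 2 to compound 3. Nothing at hand explains why this exchange lowers the number.

The compounds shown leave open whether the lower number goes with the carbonyl alone or also depends on the methoxyethyl tail, a question that a smaller group on the same nitrogen, such as acetyl or methoxycarbonyl, could help to settle. Also open, going by these compounds, is how far the position tolerates other chains, such as a longer ether chain or a chain ending in an amine or a carboxylic acid.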